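A Hydroxy Group Added to Compound 3

The compounds below may be only part of what the source reports. "The series", "measured", "known", "first", "only" and "open" are said of these compounds alone.

In a functional assay on the whole organism (Hindlimb, strain albino) with Mus musculus as the target, in the maximal electroshock model, with a stated time of 0.5 h (on this read-out lower numbers stand for an effect already at smaller amounts and higher numbers for an effect only at larger amounts of compound), compound 3 (`COc1ccc(C2CC(Nc3nc4ccccc4s3)=NN2C(C)=O)cc1`) gives 226 umol/kg. Compound 2 (`CC(=O)N1N=C(Nc2nc3ccccc3s2)CC1c1ccc(Cl)cc1`) gives 209 umol/kg, and compound 1 (`COc1ccc(C2CC(Nc3nc4ccc(Cl)cc4s3)=NN2C(C)=O)cc1O`) gives 127 umol/kg. Both numbers lie within the usual scatter of the value for compound 3, so the three compounds cannot be ranked.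

Compound 4 (`COc1ccc(C2CC(Nc3nc4ccccc4s3)=NN2C(C)=O)cc1O`) differs from compound 3 by one change: hydroxy in place of hydrogen on an aromatic carbon. This turns 4-methoxyphenyl into 3-hydroxy-4-methoxyphenyl. Among the compounds with values here, the only measured step, a 1.1-fold higher number from compound 2 to compound 3 (0.03 log units; within the scatter), places methoxy in place of chloro on an aromatic carbon, so it bears only loosely on a new hydroxy and shows no shift beyond the scatter. Compound 1 also carries the 3-hydroxy-4-methoxyphenyl group, and its 127 umol/kg stays within the scatter of the value for compound 3. Within the data shown here, no measured step isolates the hydroxy group itself. The expected change is a 1.3-fold lower number from compound 3 to compound 4 (0.11 log units; within the scatter), which is not expected to exceed the scatter. For compound 4 the estimated value is 175 umol/kg, with an expected range of 85 umol/kg to 360 umol/kg.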

Compound 4, dose for half-maximal effect: 259 umol/kg
Compound 4: middle estimate off by 1.5-fold (0.17 log units), on the low side; measured number inside the range.
By their numbers in this assay, from the lowest: compounds 1, 2, 3 and 4 (each within the scatter of the next, the first and the last beyond it).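

In this assay, hydroxy in place of hydrogen on an aromatic carbon, ortho to a methoxy group, gives a 1.1-fold higher number from compound 3 to compound 4 (0.06 log units; within the scatter), so this position takes the new group without a shift that can be told from the scatter. Exchanging the whole aryl group gives a 1.2-fold higher number from compound 2 to compound 4 (0.09 log units; within the scatter), so 3-hydroxy-4-methoxyphenyl and 4-chlorophenyl cannot be told apart here either. With 3-hydroxy-4-methoxyphenyl held constant, hydrogen in place of chloro gives a 2.0-fold higher number from compound 1 to compound 4 (0.31 log units; beyond the scatter), a modest step beyond the scatter and the only one of the three, so the visible change among these compounds lies at the chloro, not at the hydroxy.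

Nothing given here explains any of these steps. On these data alone, whether an amine, a carboxylic acid or a longer chain such as ethoxy at this position would shift the number beyond the scatter remains open.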